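Compound 3 to compound 4: growth inhibition notes

The compounds below may be only part of what the source reports. "The series", "measured", "known", "first", "only" and "open" are said of these compounds alone.

In a functional assay on HCT-116 cells (Homo sapiens) for inhibition, read by CCK-8 assay, with a stated time of 72 h, tested at 8 uM (a higher number here means more inhibition of growth at the concentration tested, a lower number less inhibition of growth), compound 1 `COc1ccc(SCc2ccc(/C=C/C(=O)Nc3ccccc3N)cc2)cc1OC` gives 49.5%, compound 2 `Nc1ccccc1NC(=O)/C=C/c1ccc(CSc2cccc(F)c2)cc1` gives 3.22% and compound 3 `Nc1ccccc1NC(=O)/C=C/c1ccc(CSc2ccc(F)cc2)cc1` gives 20.2%, which places compound 3 second highest of the three. Compound 4 `CC(C)(C)c1ccc(SCc2ccc(/C=C/C(=O)Nc3ccccc3N)cc2)cc1` has tert-butyl in place of fluoro on an aromatic carbon. Among the measured compounds shown here, no measured step makes this exact change, but three steps alter the same aryl group on sulfur. 4-Fluorophenyl in place of 3,4-dimethoxyphenyl gives the modest a number 29.3 percentage points lower from compound 1 to compound 3 (beyond the scatter), 3-fluorophenyl in its place gives the large a number 46.3 percentage points lower from compound 1 to compound 2 (beyond the scatter), and moving between the two fluorophenyl groups gives the modest a number 17 percentage points higher from compound 2 to compound 3 (beyond the scatter). A modest rise in this assay is expected, with the estimated step being a number 12.8 percentage points higher from compound 3 to compound 4 (beyond the scatter), though the direction remains uncertain. The expected value for compound 4 is 33%, within a range of 10% to 58%.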

Compound 4, percent growth inhibition at one concentration: 39%
Compound 4: the middle estimate sits 6 percentage points below what was measured, within the range that was stated.
By their numbers in this assay, from the lowest: compound 2; then compound 3; then compound 4; then compound 1.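

In this assay, tert-butyl in place of fluoro gives a number 18.8 percentage points higher from compound 3 to compound 4 (beyond the scatter) and shows that this position accepts a larger all-carbon group. Against the 3-fluorophenyl group the change is a number 35.8 percentage points higher from compound 2 to compound 4 (beyond the scatter), so oxygen on this aryl group is not required for a high number. The 3,4-dimethoxyphenyl group still leads, with a number 10.5 percentage points lower from compound 1 to compound 4 (beyond the scatter), and nothing measured here explains these steps. From the compounds shown here alone, whether an amine, a carboxylic acid or a longer chain in place of tert-butyl would raise the number remains open.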